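This account rests on a few compounds, and the source may have more. Where it says the series, first, only, none or still open, it means among the compounds named here.

Measured so far:
compound 1, `Cc1cccc(NC(=O)CCN2CCN(c3ccccn3)CC2)c1`: 30%;
compound 2, `Cc1cccc(NC(=O)CCN2CCN(c3ncccn3)CC2)c1`: 13.7%;
compound 3, `Cc1cccc(NC(=O)CN2CCN(c3ncccn3)CC2)c1`: 64.6%.

All three were tested in a functional assay on cells for agonist activity at D(4) dopamine receptor (Homo sapiens), read by TR-FRET and cAMP accumulation, with a stated time of 30 min; a lower number here means a smaller maximal response, a higher number a larger maximal response. Compound 1 and compound 2 share one core and differ only in that compound 1 carries pyridin-2-yl in place of pyrimidin-2-yl on an amine nitrogen in a ring; this single change produced a number 16.3 percentage points higher from compound 2 to compound 1 (beyond the scatter). Compound 3 has a different core from compound 2, and the difference between the two cores is not broken down here. Among the three, compound 3 gives the largest response.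

Compound 4, `Cc1cccc(NC(=O)CN2CCN(c3ccccn3)CC2)c1`, has not yet been tested. It differs from compound 3 by pyridin-2-yl in place of pyrimidin-2-yl on an amine nitrogen in a ring, the same change at the same place as that seen between the two measured compounds. For compound 4 the expected step is a number 13.4 percentage points higher from compound 3 to compound 4 (beyond the scatter), because the earlier change gave a number 16.3 percentage points higher from compound 2 to compound 1 (beyond the scatter). Compound 4 is therefore estimated at 78%, with a likely range from 58% to 100%.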

Compound 4, largest response reached (Emax), in percent of the reference or control that the assay uses: 64.2%
Estimate against measurement, compound 4: 13.8 percentage points above, and the stated range covers the measured number.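

Putting pyridin-2-yl in place of pyrimidin-2-yl on the core of compound 3 gave, in this assay, a number 0.4 percentage points lower from compound 3 to compound 4 (within the scatter). The change therefore did not carry over with the same size from one core to the other: the same change on two cores in this assay, a number 16.3 percentage points higher (beyond the scatter) from compound 2 to compound 1 and a number 0.4 percentage points lower (within the scatter) from compound 3 to compound 4, 16.7 percentage points apart, beyond the scatter of two such steps

This shows that, in these two pairs, the size of the step depends on the core, but two pairs do not show why, nor what the change would do on any further core. The compounds shown leave open whether a phenyl or pyrazin-2-yl group on that amine nitrogen in a ring would match either step. They also leave open how a longer chain in the core would affect the gap.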